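Series notes: acetyl in place of bromo

The source may hold more compounds than are shown below. What is called first, only, known or untested is meant among the compounds shown, and "the series" means these compounds.

Measured compounds:
compound 1, `O=C(O)CC1(c2ccc(OCC3COc4ccc(Cl)cc4O3)cc2)COC1` — 66%
compound 2, `CC#C[C@@H](CC(=O)O)c1ccc(OC[C@H]2COc3ccc(Br)cc3O2)cc1` — 69%

In a functional assay on HEK293 cells for agonist activity at Free fatty acid receptor 1 (Homo sapiens), read by fluorescence and calcium flux, with a stated time of 10 min (a lower number here means a smaller maximal response, a higher number a larger maximal response), compound 1 gives 66%, and compound 2 gives 69%. Compound 2 has the higher of the two numbers, but the two lie within the scatter of each other, so no order between them can be read from these values. For the measured compounds named here, compound 1 and compound 2 differ in more than one place, and no single step between measured compounds is available.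

Compound 3, `CC#C[C@@H](CC(=O)O)c1ccc(OC[C@H]2COc3ccc(C(C)=O)cc3O2)cc1`, has not been measured in this assay. It differs from compound 2 in one place: acetyl in place of bromo on an aromatic carbon. The change sits on the fused two-ring part of the shared core, on an aromatic carbon meta to a fused ring and para to a fused ring.

Going by the values given here, with no measured step to guide the size, the expectation rests only on the two measured values, which agree closely. The step of a number 4 percentage points lower from compound 2 to compound 3 (within the scatter) is expected to be small, in either direction, or none beyond the scatter. For compound 3 the estimate in this assay is 65%, with a range from 45% to 85%.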

Compound 3, largest response reached (Emax), in percent of the reference or control that the assay uses: 51%
Beside the measured number, compound 3's estimate is 14 percentage points above it, and the stated range covers the measured number.
By their numbers in this assay, from the lowest: compound 3; then compounds 1 and 2 (each within the scatter of the next).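

In this assay, the series now has its first comparison in one place: acetyl in place of bromo on an aromatic carbon, meta to a fused ring and para to a fused ring, gives a number 18 percentage points lower from compound 2 to compound 3 (beyond the scatter) on this read-out. This aromatic carbon is therefore not indifferent to the group it carries, since exchanging one bromine for the 3 heavy atoms of acetyl, with its double bond outside aromatic rings and its hydrogen-bond acceptor, moves the maximal response, although compound 3 at 51% keeps a clear response. For the compounds shown here, nothing measured so far bears on what lies behind this step.

A single pair cannot show whether the step follows the count of heavy atoms, the carbonyl or acetyl as a whole, and compound 1 differs from compound 2 in more than one place, so it adds nothing on this point. Open questions are where a nitrile, a methoxy group or a primary amide at the same aromatic carbon would fall relative to bromo and acetyl, and whether acetyl would give a step of similar size on the core of compound 1.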